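Working notes on macrophage cytotoxicity in the series

The source may report more compounds than this note shows. Statements on the series, on what has been measured and on what is new or still open speak of the compounds shown alone.

For the measured compounds named here, three analogues of the shared core have numbers so far. In an ADME assay on cells (Macrophage, Homo sapiens) for cytotoxicity, read by MTT assay, with a stated time of 24 h (a lower number here means that less compound is tolerated, a higher number that more compound is tolerated), compound 1 `CC(O)Cn1c([N+](=O)[O-])cnc1/C=C/c1cccc(F)c1` gives 1030 nM. In this assay compound 2 `COc1ccccc1/C=C/c1ncc([N+](=O)[O-])n1CC(C)O` gives 480 nM, and compound 3 `CC(O)Cn1c([N+](=O)[O-])cnc1/C=C/c1ccc([N+](=O)[O-])cc1` gives 410 nM. Compound 2 stands second highest of the three: its nearest neighbour is compound 3, within the scatter, and its furthest is compound 1, whose higher number lies beyond the scatter. Compound 4 `CC(O)Cn1c([N+](=O)[O-])cnc1/C=C/c1ccccc1[N+](=O)[O-]` is not yet measured. Compound 4 differs from compound 2 in one place: nitro in place of methoxy on an aromatic carbon. Going by the values given here, no pair of measured compounds follows this exact exchange, so the expectation rests on what the three values show: compound 3, which also carries a nitro group on the aromatic ring, gives 410 nM, within the scatter of compound 2. The step from compound 2 to compound 4 is therefore expected to be a 1.1-fold lower number from compound 2 to compound 4 (0.03 log units; within the scatter), not beyond the scatter in either direction. Compound 4 is estimated at 450 nM, with a range from 200 nM to 1000 nM.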

Compound 4, half-maximal cytotoxic concentration: 1090 nM
The estimate for compound 4 lay 2.4-fold (0.38 log units) below the measured number, and the stated range ends below it.
By their numbers in this assay, from the lowest: compounds 3 and 2 (each within the scatter of the next); then compounds 1 and 4 (each within the scatter of the next).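

In this assay the exchange of methoxy for nitro, on an aromatic carbon ortho to a large group, gives a 2.3-fold higher number from compound 2 to compound 4 (0.36 log units; beyond the scatter), so this place responds to the change, though the step is modest. A nitro group on the aromatic ring does not settle the number by itself: compound 3 gives 410 nM and compound 4 gives 1090 nM, so where the nitro group sits appears to matter in this pair. No measurement at hand offers a reason for the step.

Going by these compounds, whether an amine or a carboxylic acid on this same aromatic carbon would stay near the number of compound 2 or that of compound 4 remains open. On these data alone, this exchange rests on a single pair, so its size at any other aromatic carbon also remains open.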